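Adding a second tetrazole to compound 2

The source may hold more compounds than are shown below. What is called first, only, known or untested is meant among the compounds shown, and "the series" means these compounds.

Compound 1 `O=C(Nc1cccc(-c2nn[nH]n2)c1)c1cccc(-c2nn[nH]n2)c1` gives 1.6 mg/kg
Compound 2 `O=C(Nc1ccccc1)c1cccc(-c2nn[nH]n2)c1` gives 4.5 mg/kg

In a functional assay on the whole organism with Rattus norvegicus as the target, at a dose of 25 mg/kg by the intravenous route (on this read-out higher numbers stand for an effect only at larger amounts of compound and lower numbers for an effect already at smaller amounts), compound 2 holds the higher of the two numbers, and compound 1 lies beyond the scatter below it. Compound 3 (`O=C(Nc1ccc(-c2nn[nH]n2)cc1)c1cccc(-c2nn[nH]n2)c1`) differs from compound 2 by one change: 2H-tetrazol-5-yl in place of hydrogen on an aromatic carbon, para to a large group (2H-tetrazol-5-yl in place of hydrogen on an aromatic carbon). Going by the values given here, one measured step bears on this. It replaces that group with hydrogen and runs the opposite way (a 2.8-fold higher number from compound 1 to compound 2 (0.45 log units; beyond the scatter)), a modest step beyond the scatter. A step of similar modest size towards a lower number is therefore expected, although compound 3 carries the group at a different place from compound 1, which leaves the transfer uncertain. The expected change is a 2.3-fold lower number from compound 2 to compound 3 (0.35 log units; beyond the scatter) with wide uncertainty. In this assay compound 3 is expected at 2 mg/kg within an estimated range of 0.7 mg/kg to 5.5 mg/kg overall.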

Compound 3, dose for 50% inhibition: 0.05 mg/kg
Estimate against measurement, compound 3: 40-fold (1.60 log units) above; the measured number lies below the stated range.
By their numbers in this assay, from the lowest: compound 3; then compound 1; then compound 2.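

In this assay the entry of 2H-tetrazol-5-yl in place of hydrogen on an aromatic carbon, para to a large group, gives a 90-fold lower number from compound 2 to compound 3 (1.95 log units; beyond the scatter) and so counts as a large step. Within these three compounds, the size of the effect of this group therefore depends strongly on where it sits: compound 1, with the same group at another place, gives 1.6 mg/kg while compound 3 gives 0.05 mg/kg on the same read-out. Nothing available here explains this difference between the two places.

The compounds shown leave open whether a carboxylic acid or an amine at this same place would produce a step of similar size. They also leave open how much of the low number of compound 3 depends on the 2H-tetrazol-5-yl it shares with compound 2.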